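The compounds below may be only part of what the source reports. "The series", "measured", "known", "first", "only" and "open" are said of these compounds alone.

Two compounds in this series carry a measurement so far. Compound 1 `O=C(Nc1ccc(-c2cscn2)cc1)C1CCN(Cc2ccc(F)c(F)c2)C1` gives 8000 nM in a functional assay on A-375 cells (Homo sapiens) for activation, with a stated time of 3 days; on this read-out higher numbers stand for an effect only at larger amounts of compound and lower numbers for an effect already at smaller amounts. Compound 2 `O=C(Nc1ccc(-c2cscn2)cc1)C1CCCN(C(=O)c2ccc(F)c(F)c2)C1` in this assay reaches only a limit of the measurement, > 20000 nM, and no number. Compound 2 thus sits at the limit of > 20000 nM in this assay, at which 1 of the 2 values shown sits, the weaker end of what has been seen, while compound 1 has a measured number. Compound 3 `O=C(Nc1ccc(-c2cscn2)cc1)C1CCCN(Cc2ccc3cn[nH]c3c2)C1` has not yet been measured in this assay. Its difference from compound 2 is (1H-indazol-6-yl)methyl in place of (3,4-difluorophenyl)carbonyl on an amine nitrogen in a ring; compound 3 keeps the core of compound 2 and exchanges the (3,4-difluorophenyl)carbonyl for the (1H-indazol-6-yl)methyl on the amine nitrogen in a ring. Going by the values given here, no step between measured compounds exists to guide the estimate. The author expects the step of an at least 3.3-fold lower number from compound 2 to compound 3 (0.52 log units; beyond the scatter) to run toward an effect at smaller amounts, beyond the scatter. Compound 3 is estimated at 6000 nM, with a range from 1500 nM to 25000 nM.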

Compound 3, half-maximal effective concentration: > 20000 nM
Compound 3: only a limit was reported (the forecaster's own chance of this, stated with the estimate: 25%); middle value at least 3.3-fold (0.52 log units) away from the limit.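

In this assay, going by these compounds alone, compound 2 and compound 3 both reach only a limit of the measurement and no number, so no step between them can be read: the limit of > 20000 nM in this assay, at which 2 of the 3 values shown sit. The compounds shown leave open whether the exchange of the (3,4-difluorophenyl)carbonyl for the (1H-indazol-6-yl)methyl changes the read-out at all.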